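Chain extension on the imide nitrogen of the furanylmethyl series

This account rests on a few compounds, and the source may have more. Where it says the series, first, only, none or still open, it means among the compounds named here.

Compound 3 `Cn1c(Cc2cccs2)nc2c1c(=O)n(CC1CC1)c(=O)n2Cc1ccco1` has the second highest number of the three measured in an assay on HEK293 cells for displacement of a labelled ligand from adenosine receptor A2b (Homo sapiens) (a lower number here means a stronger inhibitor, a higher number a weaker inhibitor), giving 35.5 nM. Compound 2 `CCn1c(=O)c2c(nc(Cc3cccs3)n2C)n(Cc2ccco2)c1=O` gives 7.41 nM, and compound 1 `CCSCCn1c(=O)c2[nH]c(Cc3cccs3)nc2n(Cc2ccco2)c1=O` gives 275 nM. Compound 4 `CCSCCn1c(=O)c2c(nc(Cc3cccs3)n2C)n(Cc2ccco2)c1=O` differs from compound 3 by (ethylsulfanyl)methyl in place of cyclopropyl on a saturated chain carbon bound to an aromatic nitrogen. Within the data shown here, the only step at this position, a 4.8-fold higher number from compound 2 to compound 3 (0.68 log units; beyond the scatter), shows that a larger group there raised the number modestly. Compound 1, which carries the same ethylsulfanyl chain but differs elsewhere, only shows its own value beside compound 2. Compound 4 is therefore expected to land between compounds 2 and 3, with a step of a 1.8-fold lower number from compound 3 to compound 4 (0.25 log units; within the scatter) in this assay. Compound 4 is estimated at 20 nM, within 5 nM to 80 nM.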

Compound 4, inhibition constant: 89.1 nM
Estimate against measurement, compound 4: 4.5-fold (0.65 log units) below, outside the stated range (above it).
By their numbers in this assay, from the lowest: compound 2; then compound 3; then compound 4; then compound 1.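

Among the chains at this place in this assay, 2-(ethylsulfanyl)ethyl gives the highest number, with a 2.5-fold higher number from compound 3 to compound 4 (0.40 log units; beyond the scatter) and a 12-fold higher number from compound 2 to compound 4 (1.08 log units; beyond the scatter) together placing it above both cyclopropylmethyl and ethyl. With that chain held, methyl in place of hydrogen on an aromatic nitrogen gives a 3.1-fold lower number from compound 1 to compound 4 (0.49 log units; beyond the scatter) and shows that this second place also moves the number.

Open, as far as these compounds go, is whether a longer plain carbon chain such as butyl, or a chain ending in an amine, would give a still higher number. No supporting evidence accounts for these steps.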